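This account rests on a few compounds, and the source may have more. Where it says the series, first, only, none or still open, it means among the compounds named here.

Three related compounds have been measured in a functional assay; on this read-out higher numbers stand for weaker inhibition and lower numbers for stronger inhibition. Compound 1 `CC(C)=CCOc1ccc2c(c1)OC(c1ccccc1F)CC2=O` gives 6360 nM, compound 2 `CC(C)=CCOc1cc(O)c2c(c1)OC(c1ccccc1)CC2=O` gives 7320 nM, and compound 3 `CC(C)=CCOc1cc(O)c2c(c1)OC(c1ccccc1F)CC2=O` gives 5300 nM. Compound 3 therefore stands level with the other two, as its gaps to both lie within the scatter of repeated measurements.

The next compound to be tested is compound 4 `CC(C)=CCOc1cc(O)c2c(c1)OC(c1ccc(F)cc1)CC2=O`. It differs from compound 3 in one place: 4-fluorophenyl in place of 2-fluorophenyl on a saturated ring carbon. In words, this is 4-fluorophenyl in place of 2-fluorophenyl on a saturated ring carbon, so the atoms stay the same but are joined differently.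

Among the measured compounds shown here, two measured steps bear on this change. The closer one puts fluoro in place of hydrogen on an aromatic carbon and gives a 1.4-fold lower number from compound 2 to compound 3 (0.14 log units; within the scatter). The other puts hydroxy in place of hydrogen on an aromatic carbon and gives a 1.2-fold lower number from compound 1 to compound 3 (0.08 log units; within the scatter). Both are within the scatter. For the measured compounds named here, no measured pair shows what happens when 2-fluorophenyl gives way to 4-fluorophenyl, so the direction remains open. Going by the values given here, with such small steps so far, no change beyond the scatter is expected in this assay. The estimated step is a 1.0-fold higher number from compound 3 to compound 4 (0.02 log units; within the scatter). Compound 4 is expected to give about 5500 nM, with an estimated range from 2800 nM to 11000 nM.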

Compound 4, half-maximal inhibitory concentration: 6060 nM
The estimate for compound 4 lay 1.1-fold (0.04 log units) below the measured number, and the stated range covers the measured number.
By their numbers in this assay, from the lowest: compounds 3, 4, 1 and 2 (each within the scatter of the next).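

Moving the fluorine from 2-fluorophenyl to 4-fluorophenyl, on the saturated ring carbon next to the ring oxygen, gives in this assay a 1.1-fold higher number from compound 3 to compound 4 (0.06 log units; within the scatter) and so leaves the number within the scatter, even though the same atoms are joined differently. The change of fluoro in place of hydrogen on an aromatic carbon can now be read a second time, as a 1.2-fold lower number from compound 2 to compound 4 (0.08 log units; within the scatter) beside the earlier 1.4-fold lower number from compound 2 to compound 3 (0.14 log units; within the scatter) and both readings lie within the scatter, so neither of these two fluorophenyl compounds can be told apart from the plain phenyl compound 2 in this assay. No measurement at hand offers an explanation for these small steps.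

Among the compounds shown here, every step so far stays within the scatter, so it remains open whether anything at this position can shift the number clearly in either direction. A phenyl ring carrying an amine or a carboxylic acid, or a 3-fluorophenyl group, would test this position further, since such groups differ from the fluorophenyl groups compared here.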